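The compounds below may be only part of what the source reports. "The series", "measured", "known", "first", "only" and "open" are said of these compounds alone.

For the measured compounds named here, compound 2 `O=C(CC1c2ccccc2N=C(SCCCCCN2CCCC2)N1c1ccc(-c2ccc(F)cc2)cc1)NCc1ccc(F)cc1` gives 19800 nM in an assay on cells for inhibition of Voltage-dependent T-type calcium channel subunit alpha-1I (Homo sapiens), read by patch clamp (on this read-out lower numbers stand for stronger inhibition and higher numbers for weaker inhibition), and so shows the highest of the three numbers measured so far, although the step of a 1.5-fold higher number from compound 1 to compound 2 (0.16 log units; within the scatter) lies within the scatter. Compound 1 `O=C(CC1c2ccccc2N=C(SCCCCCN2CCCC2)N1c1ccc(-c2ccccc2)cc1)NCc1ccc(F)cc1` gives 13600 nM in this assay. Going by the values given here, compound 3 `O=C(CC1c2ccccc2N=C(SCCCCCN2CCCC2)N1c1ccc(-c2ccc(F)cc2)cc1)NCc1ccccc1` gives 5100 nM in this assay, and the step of a 3.9-fold lower number from compound 2 to compound 3 (0.59 log units; beyond the scatter) is the only change in the set that reaches beyond the scatter.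

Compound 4 `O=C(CC1c2ccccc2N=C(SCCCCCN2CCCC2)N1c1ccccc1)NCc1ccc(F)cc1` differs from compound 2 by hydrogen in place of 4-fluorophenyl on an aromatic carbon. Among the compounds with values here, no measured step removes this group. The step of a 1.5-fold higher number from compound 1 to compound 2 (0.16 log units; within the scatter) touches the same ring, but only by a fluoro, and was small; the step of a 3.9-fold lower number from compound 2 to compound 3 (0.59 log units; beyond the scatter) concerns the benzylic amide end of the molecule and does not bear on the change. Within the data shown here, the data therefore give no direction for the step from compound 2 to compound 4, and no step beyond the scatter in this assay is expected, though the range must be wide because only the small step of a 1.5-fold higher number from compound 1 to compound 2 (0.16 log units; within the scatter) informs this part of the structure. The estimate for compound 4 is 15000 nM (4000 nM to 50000 nM) in this assay, which means an expected step of a 1.3-fold lower number from compound 2 to compound 4 (0.12 log units; within the scatter).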

Compound 4, half-maximal inhibitory concentration: 664000 nM
For compound 4 the middle estimate is 44-fold (1.65 log units) below the measured one, and the stated range ends below it.
By their numbers in this assay, from the lowest: compound 3; then compounds 1 and 2 (each within the scatter of the next); then compound 4.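

In this assay, the aromatic ring at this position separates compound 1 and compound 2 from compound 4: removing the 4-fluorophenyl gives a 34-fold higher number from compound 2 to compound 4 (1.53 log units; beyond the scatter), and removing the phenyl gives a 49-fold higher number from compound 1 to compound 4 (1.69 log units; beyond the scatter). The earlier compounds shown here changed this ring only by a fluoro, with a 1.5-fold higher number from compound 1 to compound 2 (0.16 log units; within the scatter), so in these compounds a fluoro on the ring leaves the number within the scatter, whereas losing the whole ring does not. Nothing available explains the size of this loss.

Hydrogen and the two aryl groups are the only substituents shown at this position, so it remains open whether a ring is required or whether a smaller group, such as chloro, methyl or methoxy, would recover the lost inhibition. A pyridyl ring or a cyclohexyl ring in the same place would test whether the ring has to be an aromatic ring of carbon only.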